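A Hydroxynaphthyl Hydrazone Replaces Thiophene on the Shared Core

The source may report more compounds than this note shows. Statements on the series, on what has been measured and on what is new or still open speak of the compounds shown alone.

Compound 2 `CCCSc1nc(N/N=C/c2cccs2)c2nnn(Cc3ccccc3)c2n1` carries a thiophen-2-yl hydrazone on the shared core. In a functional assay on MGC-803 cells (Homo sapiens) for antiproliferative activity, read by MTT assay, with a stated time of 72 h (on this read-out higher numbers stand for weaker inhibition and lower numbers for stronger inhibition), compound 2 gives > 64000 nM, which is a limit of the assay and not a number. Compound 1 `CCCSc1nc(N/N=C/c2ccc(Cl)cc2)c2nnn(Cc3ccccc3)c2n1` gives > 64000 nM, again a limit. Compound 3 `CCCSc1nc(N/N=C(\C)c2ccc(Br)cc2)c2nnn(Cc3ccccc3)c2n1` gives 6020 nM. The step that the two limits leave unreadable from compound 1 to compound 2 stays unreadable because of the limit of > 64000 nM in this assay, at which 2 of the 3 values shown sit, while the step of an at least 10-fold lower number from compound 2 to compound 3 (1.02 log units; beyond the scatter) shows that the hydrazone end can move the number substantially. Compound 4 `CCCSc1nc(N/N=C/c2c(O)ccc3ccccc23)c2nnn(Cc3ccccc3)c2n1` differs from compound 2 by 2-hydroxynaphthalen-1-yl in place of thiophen-2-yl on a carbon with a double bond to nitrogen. Among the measured compounds shown here, as only one readable step bears on this end of the molecule, a lowering is expected but its size is uncertain: the step of an at least 2.5-fold lower number from compound 2 to compound 4 (0.40 log units; beyond the scatter) is the estimate. Compound 4 is therefore expected to give 25000 nM, within 4000 nM to 64000 nM.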

Compound 4, half-maximal inhibitory concentration: 3710 nM
Compound 4: middle estimate off by 6.7-fold (0.83 log units), on the high side, and the stated range ends above it.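

In this assay, the group on the carbon with a double bond to nitrogen proves enough on its own to bring a readable value, with an at least 17-fold lower number from compound 2 to compound 4 (1.23 log units; beyond the scatter) and an at least 17-fold lower number from compound 1 to compound 4 (1.23 log units; beyond the scatter). A 2-hydroxynaphthalen-1-yl group therefore succeeds here where thiophen-2-yl and 4-chlorophenyl do not. Both sizes are only lower bounds because of the limit: the limit of > 64000 nM in this assay, at which 2 of the 4 values shown sit.

The compounds shown leave open whether the step follows the hydroxyl or the second aromatic ring. A plain naphthalen-1-yl group, or a methoxy group in place of the hydroxyl, would separate the two.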